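The source may report more compounds than this note shows. Statements on the series, on what has been measured and on what is new or still open speak of the compounds shown alone.

Measured in an ADME assay on BaF3 cells (Mus musculus) for inhibition, read by CellTiter-Glo, with a stated time of 72 h; a lower number here means a stronger inhibitor of growth, a higher number a weaker inhibitor of growth:
- compound 1 `Cc1cc(Nc2ncc3c(n2)N(C)C(=O)N(c2cc(NC(=O)c4ccc(CN5CCC(N(C)C)C5)c(C(F)(F)F)c4)ccc2C)C3)n(C)n1`: 509 nM
- compound 2 `Cc1ccc(NC(=O)c2cccc(C(F)(F)F)c2)cc1N1Cc2cnc(NC3CC3)nc2N(C)C1=O`: 5060 nM
- compound 3 `CCN1CCN(C(=O)c2ccc(Nc3ncc4c(n3)N(C)C(=O)N(c3cc(NC(=O)c5cccc(C(F)(F)F)c5)ccc3C)C4)cn2)CC1`: 728 nM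

Compound 1, at 509 nM, and compound 3, at 728 nM, lie within the usual scatter of repeated measurements, so these two values cannot be told apart. Compound 2, at 5060 nM, lies beyond that scatter from compound 1 and is the weaker inhibitor of growth.

The next compound to be tested is compound 4 `Cc1ccc(Nc2ncc3c(n2)N(C)C(=O)N(c2cc(NC(=O)c4ccc(CN5CCC(N(C)C)C5)c(C(F)(F)F)c4)ccc2C)C3)cn1`. It keeps compound 1 intact except for one group: 6-methylpyridin-3-yl in place of 1,3-dimethyl-1H-pyrazol-5-yl on a nitrogen on an aromatic ring.

Among the measured compounds shown here, no pair of measured compounds shows this change alone, so the expectation rests on indirect evidence. Compound 3 also has a six-membered aromatic ring with 1 hetero atom on that nitrogen and gives 728 nM, although it differs from compound 1 elsewhere too. In this assay, a small move towards a lower number is therefore expected, possibly none beyond the scatter. The estimated step is a 1.5-fold lower number from compound 1 to compound 4 (0.16 log units; within the scatter). For compound 4 the expected value is 350 nM, with an estimated range from 100 nM to 1200 nM.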

Compound 4, concentration for 50% growth inhibition: 636 nM
Estimate against measurement, compound 4: 1.8-fold (0.26 log units) below; low and high end bracket the measured number.
By their numbers in this assay, from the lowest: compounds 1, 4 and 3 (each within the scatter of the next); then compound 2.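

In this assay, replacing 1,3-dimethyl-1H-pyrazol-5-yl with 6-methylpyridin-3-yl on this nitrogen gives a 1.2-fold higher number from compound 1 to compound 4 (0.10 log units; within the scatter), so the two compounds cannot be told apart. Among the compounds shown here, this is the first direct reading of the change, since compound 3 also carries a six-membered aromatic ring with 1 hetero atom there but differs from compound 1 elsewhere too. Here, with the rest of the molecule held constant, the five-membered aromatic ring with 2 hetero atoms can give way to the six-membered ring, and 2 hydrogen-bond acceptors to 1, without a difference that stands out from the scatter, although nothing measured here bears on the reason for this result.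

The compounds shown leave open whether this tolerance extends to a plain phenyl ring with no hetero atom, or to a saturated ring such as piperidine, on the same nitrogen. They also leave open whether the methyl group on the pyridine matters, as a pyridin-3-yl group without it is not among them.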